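The source may hold more compounds than are shown below. What is called first, only, known or untested is meant among the compounds shown, and "the series" means these compounds.

Working notes on the arylsulfonyl series sharing the core of compound 1 `O=S(=O)(NC1=NCCN1C(=S)SN1CCn2c1nsc2=S)c1ccccc1`. In a functional assay on KYSE-510 cells (Homo sapiens) for antiproliferative activity, read by crystal violet staining, with a stated time of 96 h (on this read-out higher numbers stand for weaker inhibition of growth and lower numbers for stronger inhibition of growth), compound 1 gives >= 20000 nM, a limit of the assay and not a number. Compound 2 `O=S(=O)(NC1=NCCN1C(=S)SN1CCn2c1nsc2=S)c1ccc(C(F)(F)F)cc1` carries trifluoromethyl on an aromatic carbon; in this assay compound 2 gives >= 20000 nM, again a limit. Compound 3 `CC(=O)Nc1ccc(S(=O)(=O)NC2=NCCN2C(=S)SN2CCn3c2nsc3=S)cc1` carries acetamido on an aromatic carbon; in this assay compound 3 gives >= 20000 nM, also a limit. Compound 3 therefore stands at the limit of >= 20000 nM in this assay, at which 3 of the 3 values shown sit, and no ordering among the three is readable. The steps a step that the two limits leave unreadable from compound 1 to compound 2, a step that the two limits leave unreadable from compound 1 to compound 3 and a step that the two limits leave unreadable from compound 2 to compound 3 are all unreadable for the same reason.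

Compound 4 `O=S(=O)(NC1=NCCN1C(=S)SN1CCn2c1nsc2=S)c1cccc(Cl)c1` differs from compound 3 by 3-chlorophenyl in place of 4-acetamidophenyl on a sulfonyl sulfur. Going by the values given here, no measured step bears on this change in a readable way, since every value so far sits at the limit. The expectation rests only on that: the step that the limit leaves unreadable from compound 3 to compound 4 is estimated to stay within the scatter. Compound 4 is expected to give about 25000 nM, with a range from 8000 nM to 80000 nM, most likely reported as a limit.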

Compound 4, concentration for 50% growth inhibition: >= 20000 nM
Compound 4 gave a limit, no number (the forecaster's own chance of this, stated with the estimate: 80%); the middle value lies beyond the limit too.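

The steps to compound 4 from compound 1, compound 2 and compound 3 cannot be read, and no ordering among the four is available: the limit of >= 20000 nM in this assay, at which 4 of the 4 values shown sit. The compounds shown leave open whether any group on the sulfonyl sulfur of the shared core gives a number rather than a limit in this assay.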